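Shifting the indole attachment on a shared sulfonyl core

The source may report more compounds than this note shows. Statements on the series, on what has been measured and on what is new or still open speak of the compounds shown alone.

Measured compounds:
compound 1 `Cn1c(=O)c(S(=O)(=O)c2ccc(F)cc2)cc2cnc(Nc3ccc4cc[nH]c4c3)nc21` 10000 nM
compound 2 `Cn1c(=O)c(S(=O)(=O)c2ccc(F)cc2F)cc2cnc(Nc3cccc4[nH]ccc34)nc21` 1500 nM
compound 3 `COc1ccc(S(=O)(=O)c2cc3cnc(Nc4cccc5[nH]ccc45)nc3n(C)c2=O)cc1` 5000 nM

In a functional assay on K562 cells (Homo sapiens) for inhibition, read by trypan blue exclusion, with a stated time of 72 h (on this read-out lower numbers stand for stronger inhibition and higher numbers for weaker inhibition), compound 2 gives the lowest of the three numbers; compound 3 is nearest and compound 1 furthest. Among the compounds with values here, the one step on record, a 3.3-fold higher number from compound 2 to compound 3 (0.52 log units; beyond the scatter), concerns the group on the sulfonyl sulfur and is modest. Compound 4 `Cc1cc2cc(Nc3ncc4cc(S(=O)(=O)c5ccc(F)cc5F)c(=O)n(C)c4n3)ccc2[nH]1` instead alters the indole: 2-methyl-1H-indol-5-yl in place of 1H-indol-4-yl on a nitrogen on an aromatic ring. Within the data shown here, no measured step isolates this change; compound 1 differs from compound 2 in both the indole and the sulfonyl group, so its value shows only that both changes together give a higher number. The direction for compound 4 is therefore open, and a step near or somewhat above the scatter is expected, a 1.3-fold higher number from compound 2 to compound 4 (0.12 log units; within the scatter). Compound 4 is estimated at 2000 nM, within 600 nM to 7000 nM.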

Compound 4, half-maximal inhibitory concentration: 750 nM
Beside the measured number, compound 4's estimate is 2.7-fold (0.43 log units) above it; the measured number falls inside the stated range.
By their numbers in this assay, from the lowest: compounds 4 and 2 (each within the scatter of the next); then compounds 3 and 1 (each within the scatter of the next).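

With the 2,4-difluorophenyl group on the sulfonyl sulfur held fixed, the indole change can now be read alone: in this assay, 2-methyl-1H-indol-5-yl replaces 1H-indol-4-yl on the nitrogen, giving a 2.0-fold lower number from compound 2 to compound 4 (0.30 log units; within the scatter). This step lies within the scatter, so these two indole groups cannot be told apart on this read-out. Nothing available explains the result. As far as these compounds go, the step changes both the attachment point and the methyl group, so the share of each remains open. From the compounds shown here alone, whether an ethyl group or an amine in place of that methyl would alter the number also remains open.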